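The source may hold more compounds than are shown below. What is called first, only, known or untested is meant among the compounds shown, and "the series" means these compounds.

In a functional assay on MGC-803 cells (Homo sapiens) for antiproliferative activity, read by MTT assay, with a stated time of 48 h (a lower number here means a stronger inhibitor, a higher number a weaker inhibitor), the measured compounds are these:

- Compound 1 `COc1ccccc1NC(=O)Nc1cccc(CNc2nccnc2Cl)c1` gives 12200 nM
- Compound 2 `CN(C)c1ccc(NC(=O)Nc2cccc(CNc3nccnc3Cl)c2)cc1` gives 11500 nM
- Compound 3 `CS(=O)(=O)c1ccc(NC(=O)Nc2cccc(CNc3nccnc3Cl)c2)cc1` gives 12300 nM

These three values lie within the scatter of one another. Compound 3 at 12300 nM therefore cannot be told apart from compound 1 or compound 2, and it stands level with both.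

The next compound is compound 4 `Cc1ccc(NC(=O)Nc2cccc(CNc3nccnc3Cl)c2)cc1` which keeps the shared core of compound 3 and carries methyl in place of methylsulfonyl on an aromatic carbon, para to a large group. Among the compounds with values here, the counted difference is methyl in place of methylsulfonyl on an aromatic carbon and no measured compound yet carries methyl at this place, so the guidance is indirect.

Within the data shown here, two measured steps bear on the question. The closer one is also a swap on an aromatic carbon, methylsulfonyl in place of dimethylamino, and it amounts to a 1.1-fold higher number from compound 2 to compound 3 (0.03 log units; within the scatter) while the change on the amide-type nitrogen amounts to a 1.1-fold lower number from compound 1 to compound 2 (0.03 log units; within the scatter) and both stay within the scatter. On the strength of these two small steps, no step beyond the scatter is expected in this assay for the new swap.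

The expected change is a 1.0-fold lower number from compound 3 to compound 4 (0.01 log units; within the scatter) as an estimate only. For compound 4 the estimated value is 12000 nM with an expected range from 7000 nM to 20000 nM before any measurement.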

Compound 4, half-maximal inhibitory concentration: 11900 nM
Beside the measured number, compound 4's estimate is 1.0-fold (0.00 log units) above it; the range from low to high includes it.
By their numbers in this assay, from the lowest: compounds 2, 4, 1 and 3 (each within the scatter of the next).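

In this assay, methyl in place of methylsulfonyl on an aromatic carbon, para to a large group, gives a 1.0-fold lower number from compound 3 to compound 4 (0.01 log units; within the scatter), so taking away the 4 heavy atoms and 2 hydrogen-bond acceptors of methylsulfonyl, leaving a single carbon with no acceptor, does not separate the two compounds. Methyl in place of dimethylamino at the same place gives a 1.0-fold higher number from compound 2 to compound 4 (0.01 log units; within the scatter), so methyl, dimethylamino and methylsulfonyl all stand level here, where earlier only the last two had been compared. On the amide-type nitrogen, 4-methylphenyl in place of 2-methoxyphenyl gives a 1.0-fold lower number from compound 1 to compound 4 (0.01 log units; within the scatter), which adds a further pair that cannot be told apart.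

The compounds shown leave open whether a carboxylic acid, an amine or a longer chain at this place, or a change in the shared core itself, would produce a step beyond the scatter. Nothing shown here accounts for why these four compounds stand level.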